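Chlorine Added to the Shared Core: An Expected Step

The source may report more compounds than this note shows. Statements on the series, on what has been measured and on what is new or still open speak of the compounds shown alone.

Compound 1, `ClCc1ccccc1Cn1cnc2c(Cl)ncnc21`, in a functional assay on COLO 205 cells (Homo sapiens) for cytotoxicity, read by sulforhodamine B assay, with a stated time of 48 h (on this read-out higher numbers stand for weaker inhibition of growth and lower numbers for stronger inhibition of growth), gives > 100000 nM, which is a limit of the assay and not a number.
Compound 2, `ClCc1cccc(Cn2cnc3ncnc(Cl)c32)c1`, gives > 100000 nM, again a limit of the assay.
Compound 3, `ClCc1cccc(Cn2cnc3c(Cl)ncnc32)c1`, gives 10500 nM.

Among the three measured compounds, compound 3 is the only one for which a concentration for total growth inhibition was actually read; the other two sit at the edge of what the assay can report, (the limit of > 100000 nM in this assay, at which 2 of the 3 values shown sit). Compound 3 therefore stands as the single point of reference for the series, and any comparison has to start from it.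

Compound 4, `ClCc1cccc(Cn2cnc3c(Cl)nc(Cl)nc32)c1`, differs from compound 3 in one place: chloro in place of hydrogen on an aromatic carbon. Among the measured compounds shown here, no step between two measured compounds of this kind exists here, so the size and direction of the change rest on expectation alone. The step from compound 3 to compound 4 is expected to be a 1.3-fold lower number from compound 3 to compound 4 (0.12 log units; within the scatter), a small shift not clearly beyond the usual scatter. The estimate for compound 4 in this assay is 8000 nM, with a range from 2500 nM to 30000 nM.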

Compound 4, concentration for total growth inhibition: 5370 nM
Compound 4: middle estimate off by 1.5-fold (0.17 log units), on the high side; low and high end bracket the measured number.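

At this position, on an aromatic carbon between two ring nitrogen atoms, chloro in place of hydrogen gives a 2.0-fold lower number from compound 3 to compound 4 (0.29 log units; within the scatter) in this assay, so the two values cannot be told apart on this read-out. Among the compounds shown here, this is the first step that can be read at all, and it shows that the position can carry a chloro group while the concentration for total growth inhibition remains a real number and not a limit of the assay. A single step of this size fixes no firm direction, so the chloro group here can be called tolerated but not better than hydrogen.

The compounds shown leave open how the same carbon behaves with a different group in place of chloro, such as an amine or a methyl group, and so whether anything at this position can move the number beyond the usual scatter. Comparison across the rest of the series also stays narrow: the limit of > 100000 nM in this assay, at which 2 of the 4 values shown sit.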